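The source may report more compounds than this note shows. Statements on the series, on what has been measured and on what is new or still open speak of the compounds shown alone.

In a functional assay on PC-3 cells (Homo sapiens) for inhibition, read by MTT assay, with stated times of 18 h and 4 h (a higher number here means a weaker inhibitor, a lower number a stronger inhibitor), compound 1, `CCCCCCOP(=O)(O)OCCSC(=S)N1CCCCCC1`, serves as the starting point. Compound 1 gives > 100000 nM, which is a limit of the assay rather than a measured number. Compound 2, `CCCCCCOP(=O)(O)OCCSC(=S)N1CCN(C)CC1`, differs from compound 1 in one place: 4-methylpiperazin-1-yl in place of azepan-1-yl on a thiocarbonyl carbon. Compound 2 gives > 100000 nM, again only a limit. Compound 3, `CCCOP(=O)(O)OCCSC(=S)N1CCCCCC1`, differs from compound 1 in another place: hydrogen in place of propyl on a saturated chain carbon, three bonds along the chain from an oxygen on an unsaturated carbon. Compound 3 gives > 100000 nM, also a limit. With both ends at a limit, the step that the two limits leave unreadable from compound 1 to compound 2 has no readable size, and the same holds for a step that the two limits leave unreadable from compound 1 to compound 3; what the three measured compounds share is the limit of > 100000 nM in this assay, at which 3 of the 3 values shown sit.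

Compound 4, `CCCOP(=O)(O)OCCSC(=S)N1CCN(C)CC1`, has not yet been measured. It differs from compound 2 in the same way that compound 3 differs from compound 1: hydrogen in place of propyl on a saturated chain carbon, three bonds along the chain from an oxygen on an unsaturated carbon. The two cores on which this change is made are those of compound 1 and compound 2, whose difference is the one already described on the thiocarbonyl carbon.

Since compound 2 already sits at a limit, and the same change left compound 3 at a limit as well, compound 4 is expected to stay at the limit too, so the step that the limit leaves unreadable from compound 2 to compound 4 is estimated to be small. Compound 4 is therefore estimated at 150000 nM, with a range from 50000 nM to 500000 nM, most likely reported only as a limit.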

Compound 4, half-maximal inhibitory concentration: > 100000 nM
Compound 4 gave a limit, no number; the forecaster's own chance of this, stated with the estimate: 85%; the middle value is on the limit's open side.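

In this assay compound 4 gives > 100000 nM, which is a limit and not a number. Compound 2 also stands at a limit, so the step from compound 2 to compound 4 cannot be read. The compounds shown leave open whether the hexyl or propyl chain, or the azepan-1-yl or 4-methylpiperazin-1-yl group on the thiocarbonyl carbon, changes inhibition at all, with every result the same: the limit of > 100000 nM in this assay, at which 4 of the 4 values shown sit.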